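The compounds below may be only part of what the source reports. "The series", "measured", "known", "first", "only" and "open" are said of these compounds alone.

Compound 2 `COc1ccc(/C=C2\SC(c3ccc(C(=O)c4ccccc4)cc3)=NC2=O)cc1` gives the lower of the two numbers recorded so far in an assay on cells for inhibition of Polyunsaturated fatty acid 5-lipoxygenase (Homo sapiens), read by HPLC, with stated times of 15 min and 10 min (on this read-out higher numbers stand for weaker inhibition and lower numbers for stronger inhibition), namely 440 nM. Compound 1 `CCC(=O)Nc1ccc(C2=NC(=O)/C(=C/c3ccc(OC)cc3)S2)cc1` gives 1840 nM in this assay. For the measured compounds named here, the only measured step, a 4.2-fold lower number from compound 1 to compound 2 (0.62 log units; beyond the scatter), exchanged one group for another on the same aromatic carbon of the shared core. Compound 3 `CCCOc1ccc(C2=NC(=O)/C(=C/c3ccc(OC)cc3)S2)cc1` arises from compound 2 by propoxy in place of benzoyl on an aromatic carbon. Going by the values given here, no measured step exchanges benzoyl for propoxy, so the step from compound 1 to compound 2 is the only guide, and it suggests that the benzoyl group went with the lower number; taking it away is therefore expected to move the number back upward, by an amount of roughly the same order. Compound 3 is thus expected to give about 1200 nM in this assay, within a range from 400 nM to 3600 nM. This estimate means a step of a 2.7-fold higher number from compound 2 to compound 3 (0.44 log units; beyond the scatter).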

Compound 3, half-maximal inhibitory concentration: 500 nM
For compound 3 the middle estimate is 2.4-fold (0.38 log units) above the measured one; measured number inside the range.
By their numbers in this assay, from the lowest: compounds 2 and 3 (each within the scatter of the next); then compound 1.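

In this assay, propoxy in place of benzoyl on this aromatic carbon gives a 1.1-fold higher number from compound 2 to compound 3 (0.06 log units; within the scatter), so a group with no ring and 4 heavy atoms matches one with a six-membered aromatic ring and 8 heavy atoms. Propoxy in place of propanoylamino gives a 3.7-fold lower number from compound 1 to compound 3 (0.57 log units; beyond the scatter), which leaves compound 1 as the only one of the three set apart from the others by more than the scatter. No measured evidence here explains why these groups give the numbers they do.

Still open, on these data alone, is whether a shorter chain such as ethoxy, a longer chain such as hexyloxy, an amine or a carboxylic acid on this carbon would give a similar number. As far as these compounds go, it is also open whether benzoyl and propoxy would still match on a different core.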